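Extending the Ether Chain on a Shared Core

The source may hold more compounds than are shown below. What is called first, only, known or untested is meant among the compounds shown, and "the series" means these compounds.

Measured compounds:
- compound 1, `Cc1nn(-c2ncnc3nc[nH]c23)c2c1C(OCc1ccccc1F)CC(=O)N2`: 78 nM
- compound 2, `Cc1nn(-c2ncnc3nc[nH]c23)c2c1C(NC(=O)c1ccccc1)CC(=O)N2`: 158 nM

Both compounds share the same core and differ only in the group attached to a saturated ring carbon. In a functional assay on HEK293 cells for agonist activity at G-protein coupled receptor 39 (Homo sapiens), read by scintillation proximity assay and inositol phosphate accumulation, with a stated time of 75 min (a lower number here means that less compound is needed, a higher number that more compound is needed for the effect), compound 1 gives 78 nM and has the lowest number of the two measured compounds. Among the measured compounds shown here, the one step known so far, a 2.0-fold higher number from compound 1 to compound 2 (0.31 log units; beyond the scatter), shows that replacing the ether group by an amide at this position raises the number modestly.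

The new compound 3, `COc1ccc(CCOC2CC(=O)Nc3c2c(C)nn3-c2ncnc3nc[nH]c23)cc1`, keeps the ether but changes what hangs from it: 4-methoxybenzyl in place of 2-fluorophenyl on a saturated chain carbon bound to an oxygen on a saturated carbon. For the measured compounds named here, no measured pair covers this exact change; the step from compound 1 to compound 2 only shows that this position tolerates replacement without a large shift. A longer chain with a different substituted ring is therefore expected to give at most a modest shift, in either direction, on the same scale as that step.

The estimate for compound 3 is 150 nM, within a range from 50 nM to 500 nM, which means an expected step of a 1.9-fold higher number from compound 1 to compound 3 (0.28 log units; within the scatter).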

Compound 3, half-maximal effective concentration: 70 nM
Compound 3: the middle estimate sits 2.1-fold (0.33 log units) above what was measured; the range from low to high includes it.
By their numbers in this assay, from the lowest: compounds 3 and 1 (each within the scatter of the next); then compound 2.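

In this assay, placing 4-methoxybenzyl in place of 2-fluorophenyl on a saturated chain carbon bound to an oxygen on a saturated carbon gives a 1.1-fold lower number from compound 1 to compound 3 (0.05 log units; within the scatter) and so leaves the two ethers indistinguishable. The earlier pair showed only that an ether and an amide at this place can differ; compound 3 adds that, with the ether kept, the side chain can go from 2-fluorobenzyl to the longer 2-(4-methoxyphenyl)ethyl with no change that stands out from the scatter. Nothing measured here explains why these two side chains give such similar numbers.

Compound 3 changes the chain length and the groups on the aromatic ring together, so the compounds shown leave open whether each change alone is neutral or whether two separate effects happen to cancel. A 2-phenylethyl ether, a 2-(2-fluorophenyl)ethyl ether and an amine in place of the ether oxygen are all absent from the compounds shown, and these would pull those questions apart.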